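This account rests on a few compounds, and the source may have more. Where it says the series, first, only, none or still open, it means among the compounds named here.

Going by the values given here, in an ADME assay on L6 cells (Rattus norvegicus) for cytotoxicity, read by resazurin assay, with a stated time of 72 h (on this read-out higher numbers stand for weaker inhibition and lower numbers for stronger inhibition), compound 1 `CN(C)C12CC(OC(=O)CN3CCCC3)C(C(c3ccccc3)C1)C(c1ccccc1)C2` gives 32700 nM, the second highest of three numbers so far. Compound 3 `O=C(CN1CCCCC1)OC1CC2(N3CCCC3)CC(c3ccccc3)C1C(c1ccccc1)C2` gives 14200 nM, lower than compound 1 by more than the scatter. Compound 2 `CN1CCN(CCC(=O)N2CCC3(N4CCCCC4)CC(c4ccccc4)C2C(c2ccccc2)C3)CC1` gives 120000 nM, higher than compound 1 by more than the scatter. Among the compounds with values here, no pair of measured compounds differs in one place, so no measured step guides the next change. Compound 4 `CN(C)C12CC(N)C(C(c3ccccc3)C1)C(c1ccccc1)C2` keeps the core of compound 1 and carries amino in place of (((pyrrolidin-1-yl)methyl)carbonyl)oxy on a saturated ring carbon. No step beyond the scatter is expected in this assay, in either direction. The estimated change is a 1.1-fold lower number from compound 1 to compound 4 (0.04 log units; within the scatter). For compound 4 the expected value is 30000 nM, with an estimated range of 9000 nM to 100000 nM.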

Compound 4, half-maximal inhibitory concentration: 40900 nM
For compound 4 the middle estimate is 1.4-fold (0.13 log units) below the measured one, and the stated range covers the measured number.
By their numbers in this assay, from the lowest: compound 3; then compounds 1 and 4 (each within the scatter of the next); then compound 2.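

In this assay, going by these compounds alone, the first single-place step at this position reads a 1.3-fold higher number from compound 1 to compound 4 (0.10 log units; within the scatter), within the scatter, so this saturated ring carbon tolerates amino in place of (((pyrrolidin-1-yl)methyl)carbonyl)oxy with no readable difference. A group of 9 heavy atoms with a five-membered ring and one of 1 heavy atom with no ring thus give numbers within the scatter of each other. No evidence on the reason accompanies this result. From the compounds shown here alone, whether hydroxyl or a longer chain ending in a carboxylic acid at this carbon would read the same stays open. Also open, going by these compounds, is whether amino reads the same with another group in place of dimethylamino.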